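Acetyl for 4-nitrophenyl on a piperazine amide

A few compounds are considered here, and "the series" means these few. Any claim that something is new, unique, unknown or untested is made for them only; others in the source may bear on it.

Compound 1: `CC(C)=CCn1c(CN2CCN(C(=O)C3CC3)CC2)nc2ccccc21` — 74.3%
Compound 2: `Cc1cccc(Cn2c(CN3CCN(C(=O)c4ccc([N+](=O)[O-])cc4)CC3)nc3ccccc32)c1` — 24.3%
Compound 3: `CC(C)CCn1c(OC2CCN(C(=O)c3ccco3)CC2)nc2ccccc21` — 30.8%

These three were tested in an assay on isolated protein for inhibition of aldehyde dehydrogenase 1A1 (Homo sapiens), read by spectrophotometry, tested at 10 uM; on this read-out higher numbers stand for more inhibition at the one concentration tested (going by the name of the read-out) and lower numbers for less inhibition. Compound 2 holds the lowest of the three numbers, but its gap to compound 3 lies within the scatter, so the two cannot be ranked; only compound 1 stands clearly above compound 2, beyond the scatter. Among the measured compounds shown here, no two measured compounds differ in a single place, so no measured step is available to guide the next one.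

Compound 4, `CC(=O)N1CCN(Cc2nc3ccccc3n2Cc2cccc(C)c2)CC1`, is the unmeasured analogue of compound 2. The change is methyl in place of 4-nitrophenyl on a carbonyl carbon. For the measured compounds named here, with no measured step of this kind, only a moderate rise is expected, of a size that may or may not exceed the scatter; the expected step is a number 13.7 percentage points higher from compound 2 to compound 4 (beyond the scatter). Compound 4 is estimated at 38%, between 15% and 62%.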

Compound 4, a percentage reported as inhibition, at one concentration (the size of the read-out at that concentration, not a potency): 70.3%
Estimate against measurement, compound 4: 32.3 percentage points below, outside the stated range (above it).
By their numbers in this assay, from the lowest: compounds 2 and 3 (each within the scatter of the next); then compounds 4 and 1 (each within the scatter of the next).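

In this assay, among the compounds shown here, this is the first step read between two compounds that differ in one place, and it is large: a number 46 percentage points higher from compound 2 to compound 4 (beyond the scatter), with methyl in place of 4-nitrophenyl on a carbonyl carbon. The group on this carbonyl carbon therefore strongly affects the inhibition read at the one concentration tested, and the much smaller methyl is compatible with a high number. Nothing available explains the step. As far as these compounds go, whether a plain phenyl or an ethyl on this carbonyl carbon would give a number nearer compound 2 or compound 4 stays open. From the compounds shown here alone, it also remains open whether the step would hold with a different group in place of the 3-methylbenzyl of these two compounds.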